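The source may hold more compounds than are shown below. What is called first, only, known or untested is meant among the compounds shown, and "the series" means these compounds.

Compound 1 `COc1ccc(N(C)c2ccnc(Cl)n2)cc1OCCBr`: 7720 nM
Compound 2 `COc1ccc(N(C)c2ccnc(Cl)n2)cc1OCCCBr`: 1240 nM
Compound 3 `COc1ccc(N(C)c2ccnc(Cl)n2)cc1OCCCCBr`: not yet measured

Among the measured compounds shown here, in a functional assay on HepG2 cells (Homo sapiens) for antiproliferative activity, read by MTT assay, with a stated time of 48 h (on this read-out lower numbers stand for stronger inhibition and higher numbers for weaker inhibition), compound 2 has the lower of the two numbers so far, 1240 nM. Compound 3 differs from it by bromomethyl in place of bromo on a saturated chain carbon, three bonds along the chain from an oxygen on an aromatic ring, which turns 3-bromopropyl into 4-bromobutyl. For the measured compounds named here, only one measured step bears on this: the same kind of change, two bonds along the chain from an oxygen on an aromatic ring, gave a 6.2-fold lower number from compound 1 to compound 2 (0.79 log units; beyond the scatter). One step cannot show a trend, so a further but smaller fall is expected, with a rise not ruled out. The expected change is a 1.8-fold lower number from compound 2 to compound 3 (0.25 log units; within the scatter). Compound 3 is estimated at 700 nM, with an expected range of 200 nM to 2500 nM.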

Compound 3, half-maximal inhibitory concentration: 168 nM
Compound 3: middle estimate off by 4.2-fold (0.62 log units), on the high side, outside the stated range (below it).
By their numbers in this assay, from the lowest: compound 3; then compound 2; then compound 1.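

In this assay, going from 3-bromopropyl to 4-bromobutyl gives a 7.4-fold lower number from compound 2 to compound 3 (0.87 log units; beyond the scatter), so the fall in the number continues at this position rather than levelling off. Over the three chains, each lengthening lowers the number and no compound shown goes against this, adding up to a 46-fold lower number from compound 1 to compound 3 (1.66 log units; beyond the scatter). Nothing available explains this dependence on chain length.

Going by these compounds, whether a longer chain, such as 5-bromopentyl, would lower the number further remains open. So does whether the chain end needs its bromine, or whether an amine or a hydroxyl group there would do as well.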